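Bromo to chloro on the furan of compound 2

This account rests on a few compounds, and the source may have more. Where it says the series, first, only, none or still open, it means among the compounds named here.

Measured so far:
- compound 1 `FC(F)(F)c1ccc(-c2noc(-c3sccc3Cl)n2)nc1` gives > 10000 nM as a limit
- compound 2 `Clc1ccc(-c2noc(-c3occc3Br)n2)cc1` gives > 10000 nM as a limit

In a functional assay on NCI-H1299 cells (Homo sapiens) for inhibition, with a stated time of 48 h, at 37 degrees C (a lower number here means a stronger inhibitor of growth, a higher number a weaker inhibitor of growth), compound 2 stands at > 10000 nM which is a limit and not a number. Compound 3 `Clc1ccc(-c2noc(-c3occc3Cl)n2)cc1` carries chloro in place of bromo on an aromatic carbon so that 3-bromofuran-2-yl becomes 3-chlorofuran-2-yl. Going by the values given here, no measured step sizes this change, so no step beyond the scatter is expected in this assay and a further limit is likely. An estimated a number no higher from compound 2 to compound 3 (the limit leaves the size open) is what is expected here. For compound 3 the estimated value is 10000 nM with an expected range from 3000 nM to 30000 nM in this assay.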

Compound 3, concentration for 50% growth inhibition: > 10000 nM
Compound 3 gave a limit, no number; the forecaster's own chance of this, stated with the estimate: 70%; the middle value lies on the limit itself.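

In this assay, no step from bromo to chloro can be read between compound 2 and compound 3, since each stands only as a limit: the limit of > 10000 nM in this assay, at which 3 of the 3 values shown sit.

The compounds shown leave open how bromo and chloro compare on a compound that gives a number rather than a limit.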